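Hydroxy for bromo on the anilino ring of compound 3

This account rests on a few compounds, and the source may have more. Where it says the series, first, only, none or still open, it means among the compounds named here.

Measured so far in a functional assay on HT29-AK cells (Homo sapiens) for cytotoxicity, read by MTT assay, with a stated time of 48 h; on this read-out lower numbers stand for stronger inhibition and higher numbers for weaker inhibition:
compound 1, `COc1ccc(Nc2nc(-c3cccc(F)c3)nc3ccc(F)cc23)cc1`, gives 42300 nM.
compound 2, `Fc1cccc(Nc2nc(-c3cccc(F)c3)nc3ccc(F)cc23)c1`, reaches only the assay limit, > 50000 nM.
compound 3, `Fc1cccc(-c2nc(Nc3ccccc3Br)c3cc(F)ccc3n2)c1`, likewise sits at the limit, > 50000 nM.

Compound 3 thus stands at a limit, not at a number, as the limit of > 50000 nM in this assay, at which 2 of the 3 values shown sit, shows. Compound 4, `Oc1ccccc1Nc1nc(-c2cccc(F)c2)nc2ccc(F)cc12`, differs from compound 3 by hydroxy in place of bromo on an aromatic carbon. The measured steps on the same nitrogen-linked ring, an at least 1.1-fold higher number from compound 1 to compound 3 (0.07 log units; that floor lies within the scatter) and a step that the two limits leave unreadable from compound 2 to compound 3, both end at a limit, so neither yields a readable size for a change at this ring. Compound 4 is therefore expected to remain weak in this assay, with a number no higher from compound 3 to compound 4 (the limit leaves the size open) likely unreadable as well. The estimate for compound 4 is 50000 nM, within a range from 15000 nM to 200000 nM, a limit being more probable than a number.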

Compound 4, half-maximal inhibitory concentration: > 50000 nM
Compound 4: only a limit was reported; the forecaster's own chance of this, stated with the estimate: 60%; the middle value sits exactly at the limit.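

Compound 4 also gives only a limit in this assay, > 50000 nM. At this aromatic carbon, ortho to a large group, hydroxy in place of bromo adds a hydrogen-bond donor and a hydrogen-bond acceptor, yet no number emerges. The one step with a floor is an at least 1.1-fold higher number from compound 1 to compound 4 (0.07 log units; that floor lies within the scatter), and the other new steps cannot be read; the series now gathers at one limit: the limit of > 50000 nM in this assay, at which 3 of the 4 values shown sit.

Going by these compounds, whether any group at this position can give a number remains open. An amine or a carboxylic acid in place of bromo would test this.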